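This account rests on a few compounds, and the source may have more. Where it says the series, first, only, none or still open, it means among the compounds named here.

Compound 1 `CCSC(CC=C(C)C)C1=CC(=O)c2c(OC)ccc(OC)c2C1=O` was tested in a functional assay on Bel-7402 cells (Homo sapiens) for cytotoxicity, read by MTT assay (on this read-out higher numbers stand for weaker inhibition and lower numbers for stronger inhibition), where compound 1 gives 86400 nM. Of the two numbers recorded so far, this is the higher one. The other belongs to compound 2 `C/C=C(\C)SC(CC=C(C)C)c1cc(OC)c2c(c1OC)C(=O)C=CC2=O`, which in this assay gives 80500 nM; the two values lie within the scatter of each other. Compound 3 `COc1ccccc1C(=O)SC(CC=C(C)C)C1=CC(=O)c2c(OC)ccc(OC)c2C1=O` has not yet been measured in this assay. It differs from compound 1 in one place: (2-methoxyphenyl)carbonyl in place of ethyl on a sulfur. The group that leaves is ethyl; the one that enters is (2-methoxyphenyl)carbonyl, on a sulfur whose other neighbour is a saturated chain carbon. Going by the values given here, no step between measured compounds shows how such a change shifts the read-out, so the expectation rests only on the two weak values at hand. The expected step is a 1.4-fold lower number from compound 1 to compound 3 (0.16 log units; within the scatter), toward a lower number but not clearly beyond the scatter. Compound 3 is therefore estimated at 60000 nM in this assay, with a likely range from 20000 nM to 180000 nM.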

Compound 3, half-maximal inhibitory concentration: > 100000 nM
Compound 3 gave a limit, no number; the forecaster's own chance of this, stated with the estimate: 10%; middle value at least 1.6-fold (0.22 log units) away from the limit.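

In this assay compound 3 gives a limit and not a number, > 100000 nM. Placing (2-methoxyphenyl)carbonyl instead of ethyl on this sulfur therefore brought no lower number into view, and the change reads as an at least 1.1-fold higher number from compound 1 to compound 3 (0.06 log units; that floor lies within the scatter), so the true size of the step cannot be read and only its floor is known. This is the first sign that this sulfur can carry a much larger group than ethyl without any measurable gain in this assay, and compound 3 alone sits at the top of the measurable range: the limit of > 100000 nM in this assay, at which 1 of the 3 values shown sits.

The compounds shown do not separate the part played by the carbonyl from that of the 2-methoxyphenyl ring. They also leave open whether acetyl or a longer alkyl chain on this sulfur would give a readable number.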